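The source may report more compounds than this note shows. Statements on the series, on what has been measured and on what is new or still open speak of the compounds shown alone.

Compound 2 `CCCCN(C)c1nc(C(F)(F)F)ccc1CNC(=O)C(C)c1ccc(NS(C)(=O)=O)c(F)c1` gives 0.8 nM in a functional assay on CHO-K1 cells for antagonist activity at transient receptor potential cation channel subfamily V member 1 (Homo sapiens), read by FLIPR (on this read-out lower numbers stand for stronger inhibition and higher numbers for weaker inhibition), the lower of the two numbers recorded, while compound 1 `CC(C(=O)NCc1ccc(C(F)(F)F)nc1NC1CCCCC1)c1ccc(NS(C)(=O)=O)c(F)c1` gives 20.4 nM. For the measured compounds named here, the one measured step, a 26-fold lower number from compound 1 to compound 2 (1.41 log units; beyond the scatter), shows that the group on this ring nitrogen can move the number a great deal. Compound 3 `CC(C(=O)NCc1ccc(C(F)(F)F)nc1N(C)c1ccccc1)c1ccc(NS(C)(=O)=O)c(F)c1` differs from compound 2 by phenyl in place of butyl on a nitrogen on an aromatic ring. Going by the values given here, no measured step covers a phenyl there, so the direction is uncertain; a modest weakening is expected for compound 3, namely a 3.8-fold higher number from compound 2 to compound 3 (0.57 log units; beyond the scatter), giving an estimated 3 nM with a range from 0.8 nM to 12 nM.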

Compound 3, inhibition constant: 0.9 nM
Compound 3: the middle estimate sits 3.3-fold (0.52 log units) above what was measured; the measured number falls inside the stated range.
By their numbers in this assay, from the lowest: compounds 2 and 3 (each within the scatter of the next); then compound 1.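

In this assay the swap shows a 1.1-fold higher number from compound 2 to compound 3 (0.05 log units; within the scatter) and so does not separate phenyl from butyl on this nitrogen, even though phenyl brings a six-membered aromatic ring and butyl an open chain. The other step, a 23-fold lower number from compound 1 to compound 3 (1.36 log units; beyond the scatter) and large, means that two quite different groups alongside the methyl on this nitrogen both stand well apart from the cyclohexylamino of compound 1. No supporting evidence accounts for this. Still open, from the compounds shown here alone, is whether the methyl or the loss of cyclohexyl drives that step, which cyclohexyl(methyl)amino or butylamino would help to settle.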